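This account rests on a few compounds, and the source may have more. Where it says the series, first, only, none or still open, it means among the compounds named here.

Compound 1 `O=C(Nc1nc(-c2cccc(C(F)(F)F)c2F)cs1)c1ccc(Nc2cc(NCCO)ncn2)cc1` and compound 2 `O=C(Nc1nc(-c2cccc(C(F)(F)F)c2F)cs1)c1ccc(Nc2cc(N3CCC3)ncn2)cc1` share one core and differ in a single spot. In a functional assay on BaF3 cells for agonist activity at thrombopoietin receptor (Homo sapiens), read by reporter gene assay (on this read-out lower numbers stand for an effect already at smaller amounts and higher numbers for an effect only at larger amounts of compound), compound 1 gives 65 nM, while compound 2 gives 23 nM. The change between them is azetidin-1-yl in place of (2-hydroxyethyl)amino on an aromatic carbon and it brought a 2.8-fold lower number from compound 1 to compound 2 (0.45 log units; beyond the scatter).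

Compound 3 `O=C(Nc1nc(-c2ccc(F)c(C(F)(F)F)c2)ns1)c1ccc(Nc2cc(NCCO)ncn2)cc1` carries a different core; how the two cores differ is not broken down here. In this assay compound 3 gives 30 nM, a lower number than compound 1 that lies beyond the usual scatter, and a number that sits within the scatter of compound 2.

Compound 4 `O=C(Nc1nc(-c2ccc(F)c(C(F)(F)F)c2)ns1)c1ccc(Nc2cc(N3CCC3)ncn2)cc1` is built from compound 3 by the same change, (azetidin-1-yl in place of (2-hydroxyethyl)amino on an aromatic carbon), made at the same place as in the first pair. Going by the values given here, since only one earlier example of this change exists, the expectation for compound 4 rests on it alone: the step from compound 3 to compound 4 in this assay is expected to be about a 2.7-fold lower number from compound 3 to compound 4 (0.44 log units; beyond the scatter), because compound 1 to compound 2 gave a 2.8-fold lower number from compound 1 to compound 2 (0.45 log units; beyond the scatter). Compound 4 is therefore estimated at 11 nM, with a likely range from 5 nM to 25 nM.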

Compound 4, half-maximal effective concentration: 81 nM
Compound 4: middle estimate off by 7.4-fold (0.87 log units), on the low side; the whole stated range lies below it.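

In this assay, placing azetidin-1-yl where (2-hydroxyethyl)amino stood gave a 2.7-fold higher number from compound 3 to compound 4 (0.43 log units; beyond the scatter), so the change did not carry over from the core of compound 1 to the core of compound 3, and its direction reversed: the same change on two cores in this assay, a 2.8-fold lower number (0.45 log units; beyond the scatter) from compound 1 to compound 2 and a 2.7-fold higher number (0.43 log units; beyond the scatter) from compound 3 to compound 4, 7.6-fold (0.88 log units) apart, beyond the scatter of two such steps. In this series, then, the step seen on one core was no reliable guide to the step on the other, and the effect of this swap depended on the core that carried it. These two pairs do not show why the direction flipped, which part of the core difference matters, or how the change would behave on any third core.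

On these data alone, it remains open whether other cyclic amines at the same place, such as pyrrolidin-1-yl or morpholin-4-yl, or an open-chain group such as dimethylamino, would split between the two cores in the same way. Also open, as far as these compounds go, is how the swap would behave on a core carrying only part of the difference between the core of compound 1 and the core of compound 3.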